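Working notes on a small uterine series

A few compounds are considered here, and "the series" means these few. Any claim that something is new, unique, unknown or untested is made for them only; others in the source may bear on it.

Measured so far:
compound 1, `CC(C)Nc1nc(O)c2cc(Cl)ccc2n1`: 61%
compound 2, `Oc1nc(NCC2CCCCC2)nc2ccc(Cl)cc12`: 80.3%

In a functional assay on the whole organism (uterus) with Rattus norvegicus as the target, tested at 50 uM (a lower number here means a stronger effect, a higher number a weaker effect of the compound at the concentration tested), compound 1 gives 61% and compound 2 gives 80.3%. Compound 2 therefore stands at the highest of the two numbers, that is the weaker effect of the pair, and its nearest neighbour, compound 1, sits lower by a gap that is beyond the scatter. Going by the values given here, the two differ in more than one place, so no single step links them and nothing is drawn from that gap beyond what the two values show.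

Compound 3, `C[C@@H](Nc1nc(O)c2cc(Cl)ccc2n1)C1CCCCC1`, is the next point. It differs from compound 2 by methyl in place of hydrogen on a saturated chain carbon bound to a nitrogen on an aromatic ring and a saturated ring carbon. Among the compounds with values here, no measured pair shows this change, so its effect is unknown here. A change of one carbon on the chain is expected to move the read-out only modestly, with the step from compound 2 to compound 3 in this assay estimated at a number 4.3 percentage points lower from compound 2 to compound 3 (within the scatter), within or close to the scatter and without a firm direction. Compound 3 is accordingly expected to give about 76%, with a range from 58% to 94%.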

Compound 3, a percentage reported as activity, at one concentration (the size of the read-out at that concentration, not a potency): 90.7%
The estimate for compound 3 lay 14.7 percentage points below the measured number; measured number inside the range.
By their numbers in this assay, from the lowest: compound 1; then compound 2; then compound 3.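

In this assay, methyl in place of hydrogen on a saturated chain carbon bound to a nitrogen on an aromatic ring and a saturated ring carbon gives a number 10.4 percentage points higher from compound 2 to compound 3 (beyond the scatter), and a higher number here reads as a weaker effect at the concentration tested. Going by these compounds alone, this is the first step that changes a single place, and it shows that this chain carbon is not a silent position: even a methyl moves the read-out beyond the scatter, towards the weaker effect, with a step of modest size. No measurement at hand bears on why the step runs this way.

The compounds shown leave open whether the step depends on the spatial arrangement at this carbon, as compound 3 represents only a single arrangement, and whether an ethyl, a hydroxymethyl or a carboxylic acid in the same place would weaken the effect further, leave it level or reverse it. They also leave open whether methyl on the equivalent chain carbon would give a similar step with a different group in place of the saturated ring.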